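The source may hold more compounds than are shown below. What is called first, only, known or untested is meant among the compounds shown, and "the series" means these compounds.

Three compounds of a shared core have been examined in a functional assay on Huh-7 cells (Homo sapiens), read by fluorescence and BrdU incorporation, with a stated time of 48 h, tested at 10 uM; a lower number here means a stronger effect, a higher number a weaker effect of the compound at the concentration tested. Compound 1 `COc1cc(O)c(C(=O)/C=C/c2ccc(F)cc2)c(OC)c1` is reported in this assay as "not active" (no number reported), and compound 3 `COc1cc(O)c(C(=O)/C=C/c2ccccc2OC)c(OC)c1` likewise as "not active" (no number reported). For the measured compounds named here, compound 2 `COc1cccc(/C=C/C(=O)c2c(OC)cc(OC)cc2OC)c1` is the only one with a number: in this assay compound 2 gives 40%, so it stands alone as the single measured point. Compound 4 `COc1cc(OC)c(C(=O)/C=C/c2ccc(F)cc2)c(OC)c1` has not yet been tested. It differs from compound 2 in one place: 4-fluorophenyl in place of 3-methoxyphenyl on a double-bonded chain carbon bound to a double-bonded chain carbon. Going by the values given here, with no measured step of this kind to lean on, only a moderate change in this assay is expected, most likely toward a weaker effect. Compound 4 is therefore estimated at 60%, within 35% to 90%, an expected step of a number 20 percentage points higher from compound 2 to compound 4 (beyond the scatter).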

Compound 4, a percentage reported as activity, at one concentration (the size of the read-out at that concentration, not a potency): 44%
Estimate against measurement, compound 4: 16 percentage points above; the range from low to high includes it.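

In this assay, for the compounds shown here, putting 4-fluorophenyl in place of 3-methoxyphenyl gives a number 4 percentage points higher from compound 2 to compound 4 (within the scatter), the first step between two measured numbers. At this position, on a double-bonded chain carbon bound to a double-bonded chain carbon, the two aromatic groups therefore cannot be told apart in this read-out. Nothing shown here explains this result. From the compounds shown here alone, what stays open is how the read-out responds at this position to a group of another kind, such as an amine or a carboxylic acid.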